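This account rests on a few compounds, and the source may have more. Where it says the series, first, only, none or still open, it means among the compounds named here.

Measured in an ADME assay on microsomes from liver (Mus musculus) for metabolic stability, read by LC-MS, using NADPH, with a stated time of 45 min, tested at 0.5 uM; on this read-out lower numbers stand for slow clearance and higher numbers for fast clearance:

compound 1 `O=C(CCSc1nc2cc(Cl)ccc2o1)N1CCS(=O)(=O)C1`: 8.9 mL/min/g
compound 2 `O=C(CCSc1nc2cc(Cl)ccc2o1)N1CCCCC1`: 128 mL/min/g
compound 3 `CCN(CC)C(=O)CCSc1nc2cc(Cl)ccc2o1`: 108 mL/min/g

Compound 2 holds the highest number of the three. The gap to compound 3 is small, a 1.2-fold lower number from compound 2 to compound 3 (0.07 log units; within the scatter), so the two cannot be ordered. Compound 1, the only one carrying a sulfonyl in its amide ring, sits far below: a 14-fold higher number from compound 1 to compound 2 (1.16 log units; beyond the scatter) and a 12-fold higher number from compound 1 to compound 3 (1.08 log units; beyond the scatter).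

Compound 4 `CS(=O)(=O)C1CCN(C(=O)CCSc2nc3cc(Cl)ccc3o2)CC1` is compound 2 with methylsulfonyl in place of hydrogen on a saturated ring carbon. Among the measured compounds shown here, no measured pair changes a ring hydrogen for a methylsulfonyl while keeping the piperidin-1-yl, so the step has no direct precedent. For the measured compounds named here, the steps that bear on it are those into and out of compound 1, where the sulfonyl-bearing compound gave the low number, both large. Since compound 4 keeps the piperidin-1-yl of compound 2 and only adds the methylsulfonyl, a move downward in this assay is expected, beyond the scatter but smaller than a 14-fold higher number from compound 1 to compound 2 (1.16 log units; beyond the scatter). For compound 4 the expected step is a 3.7-fold lower number from compound 2 to compound 4 (0.56 log units; beyond the scatter), giving an estimate of 35 mL/min/g with a range from 12 mL/min/g to 100 mL/min/g.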

Compound 4, intrinsic clearance in a liver preparation (reported as CLH), per the amount of preparation that the assay uses: 2.6 mL/min/g
For compound 4 the middle estimate is 13-fold (1.13 log units) above the measured one; the whole stated range lies above it.
By their numbers in this assay, from the lowest: compound 4; then compound 1; then compounds 3 and 2 (each within the scatter of the next).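

In this assay the methylsulfonyl on the saturated ring carbon, three ring bonds from the ring nitrogen, gives a 49-fold lower number from compound 2 to compound 4 (1.69 log units; beyond the scatter) and this single added group accounts for a large step within the piperidin-1-yl series. Earlier, the low number appeared only with the amide ring exchanged for the 1,1-dioxo-1,3-thiazolidin-3-yl ring; compound 4 shows that a low number in this assay does not require that exchange, as the piperidin-1-yl stays in place. Nothing available explains the size of this step.

From the compounds shown here alone, whether a plain methyl, a nitrile or a carboxylic acid on the same ring carbon would give a step of similar size remains open, so the role of the sulfonyl itself is unsettled. Also open, going by these compounds, is how the methylsulfonyl behaves on a different ring carbon.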